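This account rests on a few compounds, and the source may have more. Where it says the series, first, only, none or still open, it means among the compounds named here.

Measured compounds:
compound 1 `COc1ccc(C2=NN(c3ccccc3)C(c3ccc(C)cc3)C2S(=O)(=O)CC2=NCCO2)cc1`, 64.9%
compound 2 `O=S(=O)(CC1=NCCS1)c1c(-c2ccc(Cl)cc2)noc1-c1ccc(Cl)cc1`, "not active" (no number reported)
compound 3 `COc1ccc(-c2noc(-c3ccc(C)cc3)c2S(=O)(=O)CC2=NCCS2)cc1`, "not active" (no number reported)

In a functional assay, read by Griess assay, with a stated time of 150 min, tested at 75 ug/mL (on this read-out lower numbers stand for a weaker effect and higher numbers for a stronger effect at the one concentration tested), compound 1 gives 64.9%, whereas compound 2 gives "not active" (no number reported) and compound 3 gives "not active" (no number reported). Compound 3 therefore stands without any single number on this read-out, and it shares that position with one further entry, compound 2, which also has no number. Compound 4 `COc1ccc(-c2noc(-c3ccc(C)cc3)c2S(=O)(=O)CC2=NCCO2)cc1` has not yet been measured. It differs from compound 3 by a group of 5 heavy atoms (3 carbon, 1 nitrogen, 1 oxygen; one five-membered non-aromatic ring with 2 hetero atoms) in place of a group of 5 heavy atoms (3 carbon, 1 nitrogen, 1 sulfur; one five-membered non-aromatic ring with 2 hetero atoms), on a saturated chain carbon bound to a sulfonyl sulfur. Within the data shown here, compound 1 carries the same entering group on a different core and does give a number in this assay, but no step on the shared core of compound 3 is available to size that change. The step from compound 3 to compound 4 is expected to be small, likely not beyond the usual scatter, though a modest rise cannot be ruled out. For compound 4 the estimate in this assay is 20%, with a range from 0% to 55%.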

Compound 4, a percentage reported as activity, at one concentration (the size of the read-out at that concentration, not a potency): 73%
The estimate for compound 4 lay 53 percentage points below the measured number; the whole stated range lies below it.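

No new step can be read: compound 3 has no number, so its change to compound 4 cannot be sized. The compounds shown leave open how the same ring exchange behaves on the core of compound 1. No measured evidence bears on this result.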